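Swapping Chloro for Methoxy on Compound 1

The source may report more compounds than this note shows. Statements on the series, on what has been measured and on what is new or still open speak of the compounds shown alone.

Of the compounds shown here, three have been measured in a functional assay on SMMC-7721 cells (Homo sapiens) for inhibition, read by MTT assay, with a stated time of 72 h, tested at 25 uM; a lower number here means less inhibition, a higher number more inhibition at the concentration tested (going by the name of the read-out). Compound 1 `CCc1nn(C)c(CO/N=C/c2c(C)nn(C)c2Oc2ccccc2Cl)c1Cl` gives < 80%, which is a limit of the assay rather than a number. Compound 2 `Cc1nn(C)c(Oc2ccc(OC(F)(F)F)cc2)c1/C=N\OCc1c(Cl)c(-c2ccc(F)cc2)nn1C` reaches 80% in this assay, and compound 3 `Cc1nn(C)c(Oc2ccc(F)cc2)c1/C=N\OCc1c(Cl)c(-c2ccc(Cl)cc2)nn1C` reaches 80%. Among the values measured, compound 1 stands at the limit of < 80% in this assay, at which 1 of the 3 values shown sits. Compound 4 `CCc1nn(C)c(CO/N=C/c2c(C)nn(C)c2Oc2ccccc2OC)c1Cl` differs from compound 1 in one place: methoxy in place of chloro on an aromatic carbon. Among the compounds with values here, no pair of measured compounds shows what this kind of change does, so the size of any step from compound 1 is open. Compound 4 is expected to stay close to compound 1, with a step that the limit leaves unreadable from compound 1 to compound 4 of little size, and an estimated value of 50%, between 20% and 80%.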

Compound 4, a percentage reported as inhibition, at one concentration (the size of the read-out at that concentration, not a potency): < 80%
Compound 4: no number, only a limit; the forecaster's own chance of this, stated with the estimate: 75%; the middle value lies beyond the limit too.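

Compound 1 and compound 4 each give a limit of the assay rather than a number, so no step between them can be read: the limit of < 80% in this assay, at which 2 of the 4 values shown sit.

On these data alone, the size of any change from methoxy in place of chloro on an aromatic carbon in this assay stays open.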